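This account rests on a few compounds, and the source may have more. Where it says the series, first, only, none or still open, it means among the compounds named here.

Measured so far in a functional assay (Platelet, plasma) for inhibition, with Homo sapiens as the target; on this read-out higher numbers stand for weaker inhibition and lower numbers for stronger inhibition:
- compound 1 `CC1(C(=O)NS(=O)(=O)Cc2ccc(F)cc2F)CCN(c2nc3c(cc2C#N)C(=O)OC3)CC1` gives 8760 nM.
- compound 2 `CC1OC(=O)c2cc(C#N)c(N3CCC(C(=O)NS(=O)(=O)Cc4ccccc4)CC3)nc21` gives > 300000 nM, which is a limit of the assay and not a number.
- compound 3 `CC1OC(=O)c2cc(C#N)c(N3CCC(C(=O)NS(=O)(=O)c4ccc(Cl)s4)CC3)nc21` gives > 300000 nM, again a limit of the assay and not a number.

For the measured compounds named here, compound 1 is the only member of the set with a measured number; the other two values are limits, as noted in the limit of > 300000 nM in this assay, at which 2 of the 3 values shown sit. Compound 4 `CC1(C(=O)NS(=O)(=O)c2ccc(Cl)s2)CCN(c2nc3c(cc2C#N)C(=O)OC3)CC1`, not yet measured, arises from compound 1 by 5-chlorothiophen-2-yl in place of 2,4-difluorobenzyl on a sulfonyl sulfur. Going by the values given here, the one measured step that resembles it is a step that the two limits leave unreadable from compound 2 to compound 3, and since both ends of that step sit at the limit, its size cannot be read. No readable evidence therefore bears on the change from compound 1 to compound 4, and no direction or size of step in this assay can be supported beyond the scatter; the estimate stays close to compound 1 with a wide range. Compound 4 is expected to give 15000 nM in this assay, between 3000 nM and 100000 nM, a step of a 1.7-fold higher number from compound 1 to compound 4 (0.23 log units; within the scatter) that is an estimate only.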

Compound 4, half-maximal inhibitory concentration: 1640 nM
Compound 4: the middle estimate sits 9.1-fold (0.96 log units) above what was measured; the measured number lies below the stated range.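

In this assay, 5-chlorothiophen-2-yl in place of 2,4-difluorobenzyl on a sulfonyl sulfur gives a 5.3-fold lower number from compound 1 to compound 4 (0.73 log units; beyond the scatter), the first readable size for a change at this position. The read-out therefore responds to the group on this sulfur, and the five-membered aromatic ring is accepted here in place of the six-membered one on the core of compound 1. The related step from compound 2 to compound 3 still cannot be read, as both of its values are limits of the assay: the limit of > 300000 nM in this assay, at which 2 of the 4 values shown sit.

The compounds shown leave open whether the lower number follows from the chlorine, the thiophene ring or the loss of the benzyl carbon link. An unsubstituted thiophen-2-yl or a 4-chlorophenyl on the same sulfur would help separate these three changes.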